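The source may hold more compounds than are shown below. What is called first, only, known or untested is meant among the compounds shown, and "the series" means these compounds.

Among the measured compounds shown here, in a functional assay on UO-31 cells (Homo sapiens) for antiproliferative activity, read by sulforhodamine B assay, with a stated time of 72 h (on this read-out lower numbers stand for stronger inhibition and higher numbers for weaker inhibition), compound 1 (`Cc1cc(C)nc(NS(=O)(=O)c2ccc(Nc3nncc4ccccc34)cc2)n1`) gives 3.4 nM and compound 2 (`C(=C/c1ccccc1)\C(=N\Nc1nncc2ccccc12)c1ccccc1`) gives 3.9 nM as its value, two numbers within the scatter of each other, so compound 1 stands level with the only other measured compound. Compound 3 (`O=S(=O)(Nc1ccccn1)c1ccc(Nc2nncc3ccccc23)cc1`) is still unmeasured. It carries pyridin-2-yl in place of 4,6-dimethylpyrimidin-2-yl on a sulfonamide nitrogen, and the rest of compound 1 is unchanged. For the measured compounds named here, no measured pair shows a change at this place, so the series gives no direct guide to the step in this assay and the expectation starts from the 3.4 nM of compound 1. A modest move toward a higher number is expected, though a step within the scatter would be no surprise. The estimated step (a 1.8-fold higher number from compound 1 to compound 3 (0.25 log units; within the scatter)) remains uncertain. For compound 3 the expected value is 6 nM (estimated range 1.5 nM to 30 nM).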

Compound 3, half-maximal inhibitory concentration: 44 nM
The estimate for compound 3 lay 7.3-fold (0.87 log units) below the measured number; measured number above the stated range.
By their numbers in this assay, from the lowest: compounds 1 and 2 (each within the scatter of the next); then compound 3.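

In this assay, among the compounds shown here, the group on a sulfonamide nitrogen is the first place with a readable step: pyridin-2-yl in place of 4,6-dimethylpyrimidin-2-yl gives a 13-fold higher number from compound 1 to compound 3 (1.11 log units; beyond the scatter), so the value depends strongly on this group. The change removes the methyl groups and one ring nitrogen together, and this single step cannot separate the two. Nothing measured here accounts for the size of the step.

Open, as far as these compounds go, is whether pyrimidin-2-yl without the methyl groups, or a methylpyridin-2-yl, would read closer to compound 1 or to compound 3. Also open, from the compounds shown here alone, is how a non-aromatic group on the same nitrogen, such as acetyl or a short alkyl chain, would read.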